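Sulfo Group Exchanged for Methylsulfonylpiperazine on an Octyl Chain

The compounds below may be only part of what the source reports. "The series", "measured", "known", "first", "only" and "open" are said of these compounds alone.

Measured so far in an assay on HEK293 cells for displacement of a labelled ligand from 5-hydroxytryptamine receptor 4 (Homo sapiens), read by scintillation counting; a lower number here means a stronger inhibitor, a higher number a weaker inhibitor:
compound 1 `COc1cc(N)c(Cl)cc1C(=O)NC1CCN(CCCCCO)CC1`: 63.1 nM
compound 2 `COc1cc(N)c(Cl)cc1C(=O)NC1CCN(CCCCCCCCS(=O)(=O)O)CC1`: 15800 nM
compound 3 `COc1cc(N)c(Cl)cc1C(=O)NC1CCN(CCN2CCN(S(C)(=O)=O)CC2)CC1`: 126 nM

Compound 2 stands highest of the three, beyond the scatter from both others: a 130-fold lower number from compound 2 to compound 3 (2.10 log units; beyond the scatter) and, read the other way, a 250-fold higher number from compound 1 to compound 2 (2.40 log units; beyond the scatter). Compound 4 `COc1cc(N)c(Cl)cc1C(=O)NC1CCN(CCCCCCCCN2CCN(S(C)(=O)=O)CC2)CC1` has not yet been measured. It differs from compound 2 in one place: 4-(methylsulfonyl)piperazin-1-yl in place of sulfo on a saturated chain carbon, eight bonds along the chain from an amine nitrogen in a ring.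

Within the data shown here, two measured steps bear on this. The step of a 130-fold lower number from compound 2 to compound 3 (2.10 log units; beyond the scatter) brings in the same entering group and removes a sulfo-bearing chain, though it also shortens the linker, so it is the closest guide. The step of a 2.0-fold higher number from compound 1 to compound 3 (0.30 log units; within the scatter) shows that the entering group, at the shorter spacing, sits close to compound 1. Among the measured compounds shown here, no measured step swaps these groups at the longer chain length kept in compound 4, so that part is untested.

The step from compound 2 to compound 4 is therefore expected to be a large decrease, a 130-fold lower number from compound 2 to compound 4 (2.12 log units; beyond the scatter). Compound 4 is estimated at 120 nM, with a range of 30 nM to 500 nM.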

Compound 4, inhibition constant: 15.9 nM
Beside the measured number, compound 4's estimate is 7.5-fold (0.88 log units) above it; measured number outside the range, below it.
By their numbers in this assay, from the lowest: compound 4; then compounds 1 and 3 (each within the scatter of the next); then compound 2.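

In this assay, among these compounds, exchanging sulfo for 4-(methylsulfonyl)piperazin-1-yl, eight bonds along the chain from an amine nitrogen in a ring, gives a 990-fold lower number from compound 2 to compound 4 (3.00 log units; beyond the scatter), the one step here that changes the group while keeping the chain length. The long chain remains in compound 4, so the high number of compound 2 goes with the sulfo group and not with the chain alone. With the same entering group on the shorter chain, compound 3 gives 126 nM, while compound 4 gives 15.9 nM, so the long chain carries no penalty with this group. No measurement shown here explains the size of this step.

The compounds leave open how a carboxylic acid or a simple hydroxy group would fare at the end of the long chain. They also leave open whether chains of intermediate length would carry the 4-(methylsulfonyl)piperazin-1-yl group equally well.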